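Isopropyl for 4-chlorophenyl on the ring amide nitrogen

The source may hold more compounds than are shown below. What is called first, only, known or untested is meant among the compounds shown, and "the series" means these compounds.

Compound 2 `O=C1COc2ccc(-c3cnc(Cl)c(NS(=O)(=O)c4ccc(F)cc4)c3)cc2N1c1ccc(Cl)cc1`, compound 1 `CC(C)N1C(=O)COc2ccc(-c3cnc(Cl)c(NS(=O)(=O)c4ccc(F)cc4)c3)cc21` and compound 3 `COc1ncc(-c2ccc3c(c2)N(c2ccc(Cl)cc2)C(=O)CO3)cc1NS(=O)(=O)c1ccc(F)cc1` are measured; compound 4 `COc1ncc(-c2ccc3c(c2)N(C(C)C)C(=O)CO3)cc1NS(=O)(=O)c1ccc(F)cc1` is not. In a functional assay on MCF7 cells (Homo sapiens) for antiproliferative activity, read by MTT assay, with a stated time of 72 h (on this read-out higher numbers stand for weaker inhibition and lower numbers for stronger inhibition), compound 2 gives 32800 nM, compound 1 gives 26600 nM and compound 3 gives 27600 nM. The change isopropyl in place of 4-chlorophenyl on an amide-type nitrogen in a ring gave a 1.2-fold lower number from compound 2 to compound 1 (0.09 log units; within the scatter). The two cores differ by methoxy in place of chloro on an aromatic carbon, which gave a 1.2-fold lower number from compound 2 to compound 3 (0.07 log units; within the scatter). Compound 4 arises from compound 3 by isopropyl in place of 4-chlorophenyl on an amide-type nitrogen in a ring, the same change as that made from compound 2 to compound 1, at a place described in identical words. Compound 4 is therefore expected to stay close to compound 3, with an estimated step of a 1.2-fold lower number from compound 3 to compound 4 (0.06 log units; within the scatter), because a 1.2-fold lower number from compound 2 to compound 1 (0.09 log units; within the scatter) lay within the scatter. In this assay compound 4 is estimated at 24000 nM, expected between 12000 nM and 48000 nM.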

Compound 4, half-maximal inhibitory concentration: 17000 nM
Estimate against measurement, compound 4: 1.4-fold (0.15 log units) above; measured number inside the range.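

In this assay, isopropyl in place of 4-chlorophenyl on an amide-type nitrogen in a ring gave a 1.6-fold lower number from compound 3 to compound 4 (0.21 log units; within the scatter), and this step agrees with the earlier one on the other core: the same change on two cores in this assay, a 1.2-fold lower number (0.09 log units; within the scatter) from compound 2 to compound 1 and a 1.6-fold lower number (0.21 log units; within the scatter) from compound 3 to compound 4, 1.3-fold (0.12 log units) apart, within the scatter of two such steps

Methoxy in place of chloro on an aromatic carbon gave a 1.6-fold lower number from compound 1 to compound 4 (0.19 log units; within the scatter), which likewise agrees with its earlier counterpart: the same change on two cores in this assay, a 1.2-fold lower number (0.07 log units; within the scatter) from compound 2 to compound 3 and a 1.6-fold lower number (0.19 log units; within the scatter) from compound 1 to compound 4, 1.3-fold (0.12 log units) apart, within the scatter of two such steps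

Both changes therefore carry between these two cores without a detectable difference, but every step lies within the scatter, so neither change is shown to shift the read-out, and nothing is shown for any further core.

As far as these compounds go, it remains open whether an amine or a longer chain on that nitrogen would give a step beyond the scatter. The same question stands for a nitrile or a carboxylic acid in place of the methoxy.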